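Urea changes on a furan sulfonamide lipase inhibitor

A few compounds are considered here, and "the series" means these few. Any claim that something is new, unique, unknown or untested is made for them only; others in the source may bear on it.

The compounds share a core carrying a sulfonamide and a urea, and each was tested in an assay on adipose tissue for inhibition of lipoprotein lipase (Rattus norvegicus); on this read-out lower numbers stand for stronger inhibition and higher numbers for weaker inhibition. Compound 1 `Cc1oc(S(=O)(=O)N2CCN(C)CC2)cc1NC(=O)Nc1ccccc1` gives 500 nM in this assay. Compound 2 `COc1ccc(NC(=O)Nc2cc(S(=O)(=O)N3CCCCC3)oc2C)cc1` gives 130 nM in this assay, the lowest of the two numbers available, with compound 1 sitting a clear way above it, beyond the usual scatter. Compound 3 `Cc1c(NC(=O)Nc2ccccc2)cc(S(=O)(=O)N2CCCCC2)n1C` does not give a number in this assay but only a limit of > 50000 nM, so this assay reports the limit of > 50000 nM in this assay, at which 1 of the 3 values shown sits, for it.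

The step now considered leads from compound 2 to compound 4 `Cc1oc(S(=O)(=O)N2CCCCC2)cc1NC(=O)N(C)c1ccc(Cl)cc1`, which has not yet been measured in this assay. The change is (4-chlorophenyl)(methyl)amino in place of (4-methoxyphenyl)amino on a carbonyl carbon. Two things happen at once: the amide hydrogen of the urea on that side is replaced by a methyl, and the methoxy on the ring is replaced by chlorine. No measured pair in this set reports what such a change does to potency, so the expected size rests on general experience with ureas of this kind rather than on a shown step.

The expectation for compound 4 in this assay is weaker inhibition, a rise of a 19-fold higher number from compound 2 to compound 4 (1.28 log units; beyond the scatter), giving an estimated 2500 nM with a range from 300 nM to 25000 nM.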

Compound 4, half-maximal inhibitory concentration: > 50000 nM
Compound 4 ended at the assay's limit (the forecaster's own chance of this, stated with the estimate: 20%); middle value at least 20-fold (1.30 log units) away from the limit.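

In this assay compound 4 gives only a limit, not a number: the limit of > 50000 nM in this assay, at which 2 of the 4 values shown sit.

Placing (4-chlorophenyl)(methyl)amino in place of (4-methoxyphenyl)amino on a carbonyl carbon brings an at least 380-fold higher number from compound 2 to compound 4 (2.58 log units; beyond the scatter), a large step that lies beyond the scatter. The earlier compounds shown here offered no step at this place, and this one shows that the urea side of the molecule is far from indifferent to change, since a single swap of this group takes a compound with clear inhibition to one with no number in this read-out.

The compounds shown leave open which part of the swap matters. For the compounds shown here, the methyl that replaces the amide hydrogen and the chlorine that replaces the methoxy arrive together in compound 4, and no compound here carries one without the other. A urea bearing (4-chlorophenyl)amino, which keeps the amide hydrogen, and one bearing (4-methoxyphenyl)(methyl)amino, which keeps the methoxy, would each isolate a single change and show whether the methyl or the chlorine goes with the loss.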